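A few compounds are considered here, and "the series" means these few. Any claim that something is new, unique, unknown or untested is made for them only; others in the source may bear on it.

In an assay on isolated protein for inhibition of vitamin D3 receptor (Homo sapiens), read by fluorescence polarization (on this read-out higher numbers stand for weaker inhibition and lower numbers for stronger inhibition), the three compounds examined so far all sit at the limit of the assay rather than at a number. Compound 1, `CS(=O)(=O)c1ccc(C(=O)N2CCC(C(=O)N3CCc4ccccc43)CC2)cc1[N+](=O)[O-]`, is reported in this assay only as a limit, at > 60000 nM. Compound 2, `CS(=O)(=O)c1ccc(C(=O)N2CCC(C(=O)N3CCN(c4ccc(F)cc4)CC3)CC2)cc1[N+](=O)[O-]`, likewise gives only a limit in this assay, > 60000 nM. Compound 3, `CS(=O)(=O)c1ccc(C(=O)NCCC(=O)N2CCCCC2)cc1[N+](=O)[O-]`, the starting point of the step followed here, also returns nothing but a limit in this assay, > 60000 nM. Since (the limit of > 60000 nM in this assay, at which 3 of the 3 values shown sit), compound 3 stands nowhere in particular among the values shown: it shares the same limit with the other two, and no order among them can be stated.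

Compound 4, `CS(=O)(=O)c1ccc(C(=O)NCCC(=O)N2CCCc3ccccc32)cc1[N+](=O)[O-]`, differs from compound 3 in one place: 1,2,3,4-tetrahydroquinolin-1-yl in place of piperidin-1-yl on a carbonyl carbon. Going by the values given here, no step between measured compounds is available, so the effect of this exchange has no measured counterpart here. Given that every compound shown, including compound 3 at > 60000 nM, stays at the limit, compound 4 is expected to do the same, with the step of a number no higher from compound 3 to compound 4 (the limit leaves the size open) amounting to no change beyond the scatter. The estimate for compound 4 in this assay is therefore 60000 nM, within a range of 20000 nM to 200000 nM, and most probably again reported only as a limit.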

Compound 4, half-maximal inhibitory concentration: > 60000 nM
Compound 4: a limit, no number (the forecaster's own chance of this, stated with the estimate: 85%); the middle value sits exactly at the limit.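

In this assay, compound 3 and compound 4 both give only a limit and no number, so no step can be read for 1,2,3,4-tetrahydroquinolin-1-yl in place of piperidin-1-yl: the limit of > 60000 nM in this assay, at which 4 of the 4 values shown sit.

The compounds shown leave open how the four rank against one another and which change to these structures would give a measured number.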